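Removing a Chloro Group from the Fused Ring Core

The compounds below may be only part of what the source reports. "The series", "measured", "known", "first", "only" and "open" are said of these compounds alone.

Measured compounds in a functional assay on aorta for antagonist activity at Alpha-1D adrenergic receptor (Rattus norvegicus); a lower number here means tighter binding, a higher number weaker binding:
compound 1, `CN(C)C(=O)c1cccnc1NCCCN1CCN(c2ccccc2C#N)CC1`: 10 nM
compound 2, `Cc1ccccc1N1CCN(CCCNc2ncccc2C(=O)N(C)C)CC1`: 10 nM
compound 3, `CN(C)C(=O)c1cnc2c(Cl)cccc2c1NCCCN1CCN(c2ccccc2OCC(F)(F)F)CC1`: 126 nM

Compound 3 stands apart: of the three numbers in this assay, compound 3 gives the highest, and its gap to compound 1 and to compound 2 lies beyond the usual scatter in both cases. Compound 1 and compound 2 differ from each other only in one substituent, and no change at the digits printed from compound 1 to compound 2 (within the scatter) shows that this exchange left the number unchanged within the scatter.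

Compound 4, `CN(C)C(=O)c1cnc2ccccc2c1NCCCN1CCN(c2ccccc2OCC(F)(F)F)CC1`, is not yet measured. It differs from compound 3 in one place: hydrogen in place of chloro on an aromatic carbon. For the measured compounds named here, no measured pair follows this kind of change; the only recorded step, from compound 1 to compound 2, touches a different part of the molecule and so offers no direct guide. The most that can be said is that compound 3 is the nearest reference and that its number, not those of compound 1 or compound 2, anchors any expectation.

The step from compound 3 to compound 4 is therefore expected to be small and uncertain in direction, a 1.6-fold lower number from compound 3 to compound 4 (0.20 log units; within the scatter). For compound 4 the estimate in this assay is 80 nM, within a range from 25 nM to 300 nM.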

Compound 4, dissociation constant: 100 nM
The estimate for compound 4 lay 1.3-fold (0.10 log units) below the measured number, within the range that was stated.
By their numbers in this assay, from the lowest: compounds 1 and 2 (each within the scatter of the next); then compounds 4 and 3 (each within the scatter of the next).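

In this assay, hydrogen in place of chloro on an aromatic carbon, in the six-membered aromatic ring of carbon only that is part of a fused system of two rings, gives a 1.3-fold lower number from compound 3 to compound 4 (0.10 log units; within the scatter), so the two compounds cannot be told apart. For the compounds shown here, the earlier compounds offered only one step, on a different part of the molecule, whereas this pair gives the first reading at this place and shows that the number in this assay holds without the chloro group. Nothing at hand speaks to the reason for this result.

This single exchange leaves open how other groups at this place, such as a methoxy group, a fluoro group or an amine, would read in this assay, since chloro and hydrogen are the only two seen here. It also leaves open whether chloro and hydrogen would still read alike if the trifluoroethoxy group of compound 3 and compound 4 gave way to a nitrile or a methyl group.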